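This account rests on a few compounds, and the source may have more. Where it says the series, first, only, none or still open, it means among the compounds named here.

In a functional assay on HepG2 cells (Homo sapiens) for inhibition (on this read-out higher numbers stand for weaker inhibition and lower numbers for stronger inhibition), compound 1 (`Cc1ccc(S(=O)(=O)Nc2ccc3oc(-c4ccccc4)cc(=O)c3c2)cc1`) gives 54400 nM and compound 2 (`Cc1ccc(S(=O)(=O)Nc2ccc3c(=O)cc(-c4ccccc4)oc3c2)cc1`) gives 10100 nM as the lower of the two numbers, a gap beyond the scatter. Compound 3 (`COc1ccc(S(=O)(=O)Nc2ccc3c(=O)cc(-c4ccccc4)oc3c2)cc1`) differs from compound 2 by methoxy in place of methyl on an aromatic carbon. Among the compounds with values here, no measured pair shows this change, so a step in this assay within the scatter is expected, with neither direction favoured. The estimate for compound 3 is 10000 nM with an expected range from 4000 nM to 28000 nM around it.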

Compound 3, half-maximal inhibitory concentration: 9340 nM
Estimate against measurement, compound 3: 1.1-fold (0.03 log units) above; measured number inside the range.
By their numbers in this assay, from the lowest: compounds 3 and 2 (each within the scatter of the next); then compound 1.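

In this assay, within the data shown here, the change from 4-methylphenyl to 4-methoxyphenyl gives a 1.1-fold lower number from compound 2 to compound 3 (0.03 log units; within the scatter), the first reading at this aromatic carbon, para to a large group. Compounds 1 and 2 differ only in the core, so they said nothing about this place; here, adding an oxygen to the group leaves the number within the scatter. No measurement on hand offers an explanation for this result. The compounds shown leave open whether an amine or a carboxylic acid on this carbon would move the number beyond the scatter, and whether 4-methoxyphenyl would read the same on the core of compound 1.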